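Replacing a phenyl with tert-butoxycarbonyl on compound 1

A few compounds are considered here, and "the series" means these few. Any claim that something is new, unique, unknown or untested is made for them only; others in the source may bear on it.

Three compounds sharing one core were tested in a functional assay on SK-N-SH cells (Homo sapiens) for inhibition, read by MTT assay; on this read-out lower numbers stand for stronger inhibition and higher numbers for weaker inhibition. Compound 1, `CCCCCCCCn1cc(/C=C/C(=O)c2ccc(NC(=O)CN3CCN(c4ccccc4)CC3)cc2)nn1`, gives 41400 nM. Compound 2, `O=C(CN1CCC(Cc2ccccc2)CC1)Nc1ccc(C(=O)/C=C/c2cn(Cc3ccc(Br)cc3)nn2)cc1`, gives 42900 nM, and compound 3, `CCCCCCCCCCn1cc(/C=C/C(=O)c2ccc(NC(=O)CN3CCN(c4ccccc4)CC3)cc2)nn1`, gives 39500 nM. Compound 1 stands second highest of the three numbers, yet all three lie within the scatter of one another, so no order among them can be drawn. Among the compounds with values here, the only single-point step available, a 1.0-fold lower number from compound 1 to compound 3 (0.02 log units; within the scatter), concerns a change on the chain and shows no effect beyond the scatter.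

Compound 4, `CCCCCCCCn1cc(/C=C/C(=O)c2ccc(NC(=O)CN3CCN(C(=O)OC(C)(C)C)CC3)cc2)nn1`, has not yet been measured. It differs from compound 1 by tert-butoxycarbonyl in place of phenyl on an amine nitrogen in a ring. Within the data shown here, no measured step touches this position: compound 2 carries a different ring there, but it also differs from compound 1 elsewhere, so its value alone gives no clean reading of the change. With no guidance at this site, the step is expected to stay within the scatter, so that a 1.0-fold lower number from compound 1 to compound 4 (0.00 log units; within the scatter) is the estimate for this assay. Compound 4 is therefore expected to give about 41000 nM, with a range from 15000 nM to 110000 nM.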

Compound 4, half-maximal inhibitory concentration: 38000 nM
Compound 4: the middle estimate sits 1.1-fold (0.03 log units) above what was measured, within the range that was stated.
By their numbers in this assay, from the lowest: compounds 4, 3, 1 and 2 (each within the scatter of the next).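

In this assay, within the data shown here, the first measured change at this position gives a 1.1-fold lower number from compound 1 to compound 4 (0.04 log units; within the scatter) and so puts tert-butoxycarbonyl on the amine nitrogen in the ring with no effect beyond the scatter. The two groups differ a good deal on paper: phenyl is a six-membered aromatic ring of carbon only with no hydrogen-bond acceptors, while tert-butoxycarbonyl has no ring, carries a double bond outside aromatic rings and brings two hydrogen-bond acceptors. Even so, this pair shows that a ring is not needed on this nitrogen to keep the number in the same range, although no measurement here offers an explanation for that.

From the compounds shown here alone, both groups seen on this nitrogen carry no net charge, so it remains open whether a plain hydrogen, leaving a free amine, or a group bearing a carboxylic acid would give a number beyond the scatter from compound 1. Going by these compounds, every value so far lies within the scatter of the next, so it is also open whether any change to the shared core moves the number at all.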